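This account rests on a few compounds, and the source may have more. Where it says the series, first, only, none or still open, it means among the compounds named here.

In an ADME assay on BCBL1 cells (Homo sapiens) for cytotoxicity, with a stated time of 7 days (on this read-out higher numbers stand for lower toxicity in this test and lower numbers for higher toxicity in this test), compound 1 `CCCCCCCCOc1nc(N)nc2c1ncn2/C=C1/CC1(CO)CO` gives > 20000 nM, which is a limit and not a number. From the compounds shown here alone, compound 2 `CCCCCCCCSc1nc(N)nc2c1ncn2/C=C1/CC1(CO)CO` gives > 20000 nM, again a limit, so its true place on the scale is unknown. Compound 3 `Nc1nc(SC2CCCC2)c2ncn(/C=C3/CC3(CO)CO)c2n1` differs from it by cyclopentyl in place of octyl on a sulfur. Within the data shown here, the only measured step, at another place in the molecule, is a step that the two limits leave unreadable from compound 1 to compound 2, and it offers no size to carry over. Among the measured compounds shown here, the same limit remains the sole guide: the limit of > 20000 nM in this assay, at which 2 of the 2 values shown sit. No clear change in either direction is expected, and the estimated step is a step that the limit leaves unreadable from compound 2 to compound 3. For compound 3 the estimated value is 25000 nM, with an expected range from 10000 nM to 60000 nM.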

Compound 3, half-maximal cytotoxic concentration: > 20000 nM
Compound 3 was reported as a limit; the forecaster's own chance of this, stated with the estimate: 80%; the middle value does not contradict the limit.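

No step can be read between compound 1, compound 2 and compound 3, since each result is only a limit and not a number: the limit of > 20000 nM in this assay, at which 3 of the 3 values shown sit.

From the compounds shown here alone, how far these compounds truly lie apart in this assay, and at what concentration any of them becomes toxic to these cells, stays open.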